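This account rests on a few compounds, and the source may have more. Where it says the series, first, only, none or still open, it means among the compounds named here.

Measured compounds:
Compound 1 `COc1cc(/C=C/C(=O)c2ccc(OCCCSC(=S)N3CCCC3)cc2)cc(OC)c1OC` gives 12800 nM in a functional assay on SK-N-SH cells (Homo sapiens) for inhibition, read by MTT assay, with a stated time of 72 h; on this read-out higher numbers stand for weaker inhibition and lower numbers for stronger inhibition.
Compound 2 `O=C(/C=C/c1ccc(Cl)cc1)c1ccc(OCCSC(=S)N2CCOCC2)cc1` gives 11700 nM in this assay.
Compound 3 `O=C(/C=C/c1ccc(Cl)cc1)c1ccc(OCCSC(=S)N2CCCC2)cc1` gives 18300 nM in this assay.

Compound 1 stands second highest of the three numbers, with compound 2 nearest and compound 3 furthest, and all three values lie within the scatter of one another, so no order among them can be read.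

Compound 4 `COc1cc(/C=C/C(=O)c2ccc(OCCSC(=S)N3CCN(C)CC3)cc2)cc(OC)c1OC` has not been measured. It differs from compound 1 in one place: a group of 10 heavy atoms (6 carbon, 2 nitrogen, 2 sulfur; one six-membered non-aromatic ring with 2 hetero atoms) in place of a group of 9 heavy atoms (6 carbon, 1 nitrogen, 2 sulfur; one five-membered non-aromatic ring with 1 hetero atom), on a saturated chain carbon, two bonds along the chain from an oxygen on an aromatic ring. Going by the values given here, the only measured step that touches this part of the structure is the one from compound 2 to compound 3, where a pyrrolidin-1-yl replaced a morpholin-4-yl on a thiocarbonyl carbon: a 1.6-fold higher number from compound 2 to compound 3 (0.19 log units; within the scatter). That exchange of one saturated ring for another at the same position left the number within the scatter. The change in compound 4 again exchanges the ring borne by the thiocarbonyl carbon, so no step beyond the scatter is expected in this assay, in either direction. Compound 4 is therefore estimated at 12000 nM, with a range from 5000 nM to 30000 nM, the expected step being a 1.1-fold lower number from compound 1 to compound 4 (0.03 log units; within the scatter).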

Compound 4, half-maximal inhibitory concentration: 2460 nM
Estimate against measurement, compound 4: 4.9-fold (0.69 log units) above; measured number below the stated range.
By their numbers in this assay, from the lowest: compound 4; then compounds 2, 1 and 3 (each within the scatter of the next).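

In this assay, the group borne by the saturated chain carbon, two bonds along the chain from an oxygen on an aromatic ring, proves able to shift the number beyond the scatter: a 5.2-fold lower number from compound 1 to compound 4 (0.72 log units; beyond the scatter). The earlier exchange of one saturated ring for another, on a different core, had stayed within the scatter, at a 1.6-fold higher number from compound 2 to compound 3 (0.19 log units; within the scatter), so a change at this part of the structure is not always silent. The step from compound 1 to compound 4 also brings a shorter chain along with the six-membered ring, and no explanation for the gain is available from measured evidence.

The compounds shown do not separate the effect of the ring from that of the chain length. From the compounds shown here alone, whether a piperidine ring, or a piperazine without its methyl group, would give a similar number also remains open.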